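Swapping a fluorine for hydrogen on a shared aromatic ring

The source may report more compounds than this note shows. Statements on the series, on what has been measured and on what is new or still open speak of the compounds shown alone.

Four compounds from one series share the same kind of two-ring aromatic core, joined to a phenyl ring that carries an amide. Compound 1 `CN(C)CCN1CCN(CC(=O)Nc2ccc(-c3nc4ccccc4o3)cc2)CC1` and compound 3 `CN(C)CCN1CCN(CC(=O)Nc2ccc(-c3nc4cc(F)ccc4o3)cc2)CC1` carry a long amine-bearing chain on the amide; compound 2 `Cc1cc(-c2nc3cc(F)ccc3o2)ccc1NC(=O)CCl` and compound 4 `Cc1cc(-c2nc3ccccc3o2)ccc1NC(=O)CCl` carry a chloroacetamide instead. How the two cores differ between compound 2 and compound 3 is not broken down here.

In a functional assay on A549 cells (Homo sapiens) for cytotoxicity, read by MTT assay, with a stated time of 24 h (a higher number here means a weaker inhibitor, a lower number a stronger inhibitor), compound 3 gives 16600 nM, and compound 1 gives 18700 nM. The change between them is hydrogen in place of fluoro on an aromatic carbon, and it made a step of a 1.1-fold higher number from compound 3 to compound 1 (0.05 log units; within the scatter). Compound 2 gives 64500 nM in this assay, the highest of the three numbers.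

The same change, (hydrogen in place of fluoro on an aromatic carbon), takes compound 2 to compound 4. Since the place lines of the two changes match word for word, this is the same change as before. Compound 4 is expected to sit close to compound 2, with an estimated step of a 1.1-fold higher number from compound 2 to compound 4 (0.04 log units; within the scatter), because the matching step a 1.1-fold higher number from compound 3 to compound 1 (0.05 log units; within the scatter) stayed within the scatter. The estimate for compound 4 is 70000 nM, with an expected range from 30000 nM to 160000 nM.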

Compound 4, half-maximal inhibitory concentration: 33500 nM
Estimate against measurement, compound 4: 2.1-fold (0.32 log units) above, and the stated range covers the measured number.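

Putting hydrogen where fluoro stood on the core of compound 2 gives a 1.9-fold lower number from compound 2 to compound 4 (0.28 log units; within the scatter), so compound 2 and compound 4 cannot be told apart in this assay. Set beside the same swap on the core that carries the long amine-bearing chain, the two steps also cannot be told apart: the same change on two cores in this assay, a 1.1-fold higher number (0.05 log units; within the scatter) from compound 3 to compound 1 and a 1.9-fold lower number (0.28 log units; within the scatter) from compound 2 to compound 4, 2.2-fold (0.34 log units) apart, within the scatter of two such steps Across these two pairs, then, the swap carries over from one core to the other without a step beyond the scatter, but this does not prove that the two steps are identical, and two pairs cannot show that the same would hold on any other core.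

Going by these compounds, only fluoro and hydrogen appear at this place on the aromatic carbon, so it remains open whether a methoxy group, an amine or a carboxylic acid there would give a clear step. On these data alone, it also remains open whether the pairs would still agree with a longer chain in place of the chloroacetamide.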